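A few compounds are considered here, and "the series" means these few. Any claim that something is new, unique, unknown or untested is made for them only; others in the source may bear on it.

Measured in a functional assay (Nicotiana tabacum); on this read-out higher numbers stand for weaker inhibition and lower numbers for stronger inhibition:

- compound 1 `CCC(C)Nc1nc(SC)nc2ncccc12`: 860 nM
- compound 2 `CCC(CC)Nc1nc(SC)nc2ncccc12`: 2720 nM

Of these two numbers, compound 2 holds the higher (2720 nM), which makes it the weaker inhibitor of the pair. The next structure is compound 3 `CCOCCNc1nc(SC)nc2ncccc12`, with 2-ethoxyethyl in place of pentan-3-yl on a nitrogen on an aromatic ring. Among the compounds with values here, only one measured step bears on this group, a 3.2-fold higher number from compound 1 to compound 2 (0.50 log units; beyond the scatter), a modest rise on adding a methyl to the saturated chain. No oxygen entered the chain in that step, so it is a weak guide here. With no ether chain measured yet, no clear move in this assay is expected beyond the scatter, in either direction. The expected step is a 1.1-fold higher number from compound 2 to compound 3 (0.04 log units; within the scatter). For compound 3 the estimated value is 3000 nM, with an expected range of 900 nM to 10000 nM.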

Compound 3, half-maximal inhibitory concentration: 7590 nM
Compound 3: the middle estimate sits 2.5-fold (0.40 log units) below what was measured; low and high end bracket the measured number.
By their numbers in this assay, from the lowest: compound 1; then compound 2; then compound 3.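

In this assay, replacing pentan-3-yl with 2-ethoxyethyl on a nitrogen on an aromatic ring keeps the size at 5 heavy atoms but puts an oxygen into the chain, and this gives a 2.8-fold higher number from compound 2 to compound 3 (0.45 log units; beyond the scatter). Chain size alone therefore does not set the number at this position. Measured against sec-butyl, the same group gives an 8.8-fold higher number from compound 1 to compound 3 (0.95 log units; beyond the scatter), which leaves compound 3 as the weakest inhibitor of the three, and nothing available explains why this change weakens inhibition.

The change also replaces a branched chain with an unbranched one, so the shown compounds cannot separate the effect of the oxygen from the effect of the chain's shape. A straight pentyl chain would pull these two apart, while an amine in place of the ether oxygen would show whether the oxygen itself matters.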